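Pyrazoline acetyl series: methylphenyl positional change

The source may report more compounds than this note shows. Statements on the series, on what has been measured and on what is new or still open speak of the compounds shown alone.

Two compounds have numbers in an assay on mitochondria for inhibition of Monoamine oxidase (Bos taurus); a lower number here means a stronger inhibitor, a higher number a weaker inhibitor. Compound 1 `CC(=O)N1N=C(c2ccc(O)cc2O)CC1c1cccc(C)c1` gives 50 nM in this assay. Compound 2 `CC(=O)N1N=C(c2ccccc2O)CC1c1ccccc1C` gives 300000 nM in this assay, the highest of the two numbers; compound 1 stands a long way lower, beyond the scatter. Compound 1 and compound 2 differ in two places, on the methylphenyl and on the hydroxyphenyl, so the share of each change in that gap cannot be read from these two values alone.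

Compound 3 `CC(=O)N1N=C(c2ccccc2O)CC1c1cccc(C)c1` has not been measured. Compared with compound 2, the change is 3-methylphenyl in place of 2-methylphenyl on a saturated ring carbon. The hydroxyphenyl of compound 2 is kept, so compound 3 carries the methylphenyl of compound 1 and the hydroxyphenyl of compound 2.

Since compound 1 with its 3-methylphenyl gives 50 nM while compound 2 gives 300000 nM, the step from compound 2 to compound 3 is expected to go towards a lower number, well beyond the scatter, a 60-fold lower number from compound 2 to compound 3 (1.78 log units; beyond the scatter), though part of the gap may belong to the hydroxyl that compound 3 lacks. Compound 3 is estimated at 5000 nM in this assay, within a wide range from 300 nM to 100000 nM.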

Compound 3, inhibition constant: 5500 nM
For compound 3 the middle estimate is 1.1-fold (0.04 log units) below the measured one; the range from low to high includes it.
By their numbers in this assay, from the lowest: compound 1; then compound 3; then compound 2.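

Compound 3 divides the gap between compound 1 and compound 2 into two single changes, each of which can now be read on its own in this assay. With the 2-hydroxyphenyl group kept, 3-methylphenyl in place of 2-methylphenyl on the saturated ring carbon gives a 55-fold lower number from compound 2 to compound 3 (1.74 log units; beyond the scatter), so the place of one methyl group on this ring matters greatly, although the two groups have the same counts of atoms, donors and acceptors. With the 3-methylphenyl kept, hydrogen in place of hydroxy on an aromatic carbon gives a 110-fold higher number from compound 1 to compound 3 (2.04 log units; beyond the scatter), so the large gap between compound 1 and compound 2 does not belong to either change alone, and nothing available here bears on the reason for either step.

As far as these compounds go, it remains open whether the methylphenyl step keeps its size when the additional hydroxy is present, as each change is read on a single background. Also open, from the compounds shown here alone, are how an unsubstituted phenyl or a chlorophenyl would read on the saturated ring carbon, and whether a methoxy or an amine could take the place of the hydroxy on the aromatic carbon.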